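Adding 4-methoxybenzyl to compound 1

The source may report more compounds than this note shows. Statements on the series, on what has been measured and on what is new or still open speak of the compounds shown alone.

In a functional assay on MDA-MB-231 cells (Homo sapiens) for cytotoxicity, read by MTT assay, with a stated time of 24 h (a lower number here means a stronger inhibitor, a higher number a weaker inhibitor), compound 1 (`COc1ccc2[nH]c(-c3cc(OC)c(OC)c(OC)c3)cc2c1`) reads > 30000 nM and this is a limit, not a number. Compound 2 (`COc1ccc2c(c1)c(Cc1ccc(O)cc1)c(-c1cc(OC)c(OC)c(OC)c1)n2Cc1ccc(O)cc1`) reads > 30000 nM and this too is a limit. Compound 1 therefore offers no measured potency to build on, and both compounds stand at the same mark (the limit of > 30000 nM in this assay, at which 2 of the 2 values shown sit). Compound 3 (`COc1ccc(Cn2c(-c3cc(OC)c(OC)c(OC)c3)cc3cc(OC)ccc32)cc1`) is compound 1 with 4-methoxybenzyl in place of hydrogen on an aromatic nitrogen. Among the measured compounds shown here, no measured step shows what such a change does. A small shift toward stronger inhibition in this assay is expected, while a result still at the limit is about as likely (an at least 1.2-fold lower number from compound 1 to compound 3 (0.07 log units; that floor lies within the scatter)). For compound 3 the estimated value is 25000 nM with an expected range from 5000 nM to 60000 nM on present evidence.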

Compound 3, half-maximal inhibitory concentration: > 30000 nM
Compound 3 ended at the assay's limit; the forecaster's own chance of this, stated with the estimate: 50%; middle value at least 1.2-fold (0.07 log units) from the limit.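

No step can be read between compound 1 and compound 3 in this assay, as the results for both compounds are limits, not numbers. The compounds shown leave open which change to the core of compound 1, if any, would give a measured potency in this assay instead of a limit.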